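A few compounds are considered here, and "the series" means these few. Any claim that something is new, unique, unknown or untested is made for them only; others in the source may bear on it.

Measured in a functional assay on T47D cells (Homo sapiens) for cytotoxicity, read by CCK-8 assay and cell counting, with stated times of 4 h and 2 days; on this read-out lower numbers stand for stronger inhibition and higher numbers for weaker inhibition:
Compound 1 `Oc1cccc(-c2cc(-c3ccccc3Cl)cc(-c3ccsc3)n2)c1`: 680 nM
Compound 2 `Oc1cccc(-c2cc(-c3ccc(Cl)cc3)cc(-c3ccco3)n2)c1`: 680 nM

Compound 2 stands level with compound 1, and their two values lie within the usual scatter of repeated measurements. Compound 3 `Oc1cccc(-c2cc(-c3ccc(Cl)cc3)cc(-c3ccsc3)n2)c1` has not yet been measured. It keeps the 4-chlorophenyl group and the 3-hydroxyphenyl group of compound 2, but carries thiophen-3-yl in place of furan-2-yl on an aromatic carbon, next to the ring nitrogen (thiophen-3-yl in place of furan-2-yl on an aromatic carbon). Within the data shown here, compound 1 also carries thiophen-3-yl, yet no pair of measured compounds differs in one place only, so the data offer no direct guide to this swap. In this assay, no change beyond the scatter is expected, in either direction. The expected 1.1-fold lower number from compound 2 to compound 3 (0.05 log units; within the scatter) is therefore small. For compound 3 the estimated value is 600 nM, with an expected range of 220 nM to 1600 nM.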

Compound 3, half-maximal inhibitory concentration: 680 nM
Compound 3: the middle estimate sits 1.1-fold (0.05 log units) below what was measured; measured number inside the range.
By their numbers in this assay, from the lowest: compounds 1, 2 and 3 (each within the scatter of the next).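

In this assay, among these compounds, thiophen-3-yl in place of furan-2-yl on the aromatic carbon next to the ring nitrogen gives no change at the digits printed from compound 2 to compound 3 (within the scatter), the first direct reading of a change at this position. The second single change, 4-chlorophenyl in place of 2-chlorophenyl, gives no change at the digits printed from compound 1 to compound 3 (within the scatter), so neither of these two swaps moves the number beyond the scatter. Nothing measured here offers a reason for this sameness.

The compounds shown carry only furan-2-yl or thiophen-3-yl next to the ring nitrogen, so it stays open whether an amine or a carboxylic acid there would shift the number beyond the scatter. From the compounds shown here alone, it also stays open whether a methoxy group in place of the hydroxy group of the 3-hydroxyphenyl group would change the reading.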